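Hydroxy(phenyl)methyl in place of (4-methoxybenzyl)oxy

The source may hold more compounds than are shown below. What is called first, only, known or untested is meant among the compounds shown, and "the series" means these compounds.

This account follows one step within a small set of compounds sharing a common core. Compound 1 `COc1ccc(COc2c(-c3ccccc3)c(-c3ccccc3)n3ccc(C#N)cc23)cc1` carries a (4-methoxybenzyl)oxy group, and in an assay for inhibition of Polyunsaturated fatty acid lipoxygenase ALOX15 (Oryctolagus cuniculus) (on this read-out higher numbers stand for weaker inhibition and lower numbers for stronger inhibition), compound 1 gives "not determined" (no result reported); compound 3 `COc1ccc(C(=O)Oc2c(-c3ccccc3)c(-c3ccccc3)n3ccc(C#N)cc23)cc1` likewise gives "not determined" (no result reported) on this assay. Going by the values given here, the only measured value in the set belongs to compound 2 `N#Cc1ccn2c(-c3ccccc3)c(-c3ccccc3)c(C(=O)c3ccccc3)c2c1`, which in this assay gives 43000 nM, a weak inhibition.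

Compound 4 `N#Cc1ccn2c(-c3ccccc3)c(-c3ccccc3)c(C(O)c3ccccc3)c2c1` differs from compound 1 by a single exchange: hydroxy(phenyl)methyl in place of (4-methoxybenzyl)oxy on an aromatic carbon. Among the compounds with values here, with no number for compound 1, the size and direction of this step cannot be anchored to a measured starting point, and no step between two measured compounds is available for comparison. Within the data shown here, what can be said is that the one compound with a number, compound 2, sits far toward the weak end of this assay.

On that basis compound 4 is expected to be a weak inhibitor as well, with an estimated value of 40000 nM in this assay, likely between 10000 nM and 150000 nM, and a real chance that only a limit rather than a number is reported.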

Compound 4, half-maximal inhibitory concentration: 48000 nM
Estimate against measurement, compound 4: 1.2-fold (0.08 log units) below; measured number inside the range.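

In this assay the exchange of benzoyl for hydroxy(phenyl)methyl on this aromatic carbon gives a 1.1-fold higher number from compound 2 to compound 4 (0.05 log units; within the scatter), so this read-out does not tell these two groups apart, and compound 4 at 48000 nM gives this position a second measured value, which stays in the weak range where compound 2 stands. Going by these compounds alone, neither compound 1 nor compound 3 has a number, so no step from either can be read, and the exchange of (4-methoxybenzyl)oxy for hydroxy(phenyl)methyl remains without a size or a direction. Nothing available explains why the two measured compounds read alike.

The compounds shown leave open whether a group joined to this carbon through oxygen, as in compound 1 and compound 3, would read any differently from the two groups with numbers. They also leave open whether a primary amine, a carboxylic acid or a longer alkyl chain at this position would bring the number out of the weak range, or whether a change elsewhere on the shared core, such as at the nitrile, would be needed.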